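A basic piperazine in place of a hydroxypiperidine

The source may report more compounds than this note shows. Statements on the series, on what has been measured and on what is new or still open speak of the compounds shown alone.

Compound 1 `Cc1nc(N2CCN(S(C)(=O)=O)CC2)nc2ccc(NC(=O)COc3ccc(Cl)cc3)cc12`: in a functional assay on CHO-K1 cells for antagonist activity at melanin-concentrating hormone receptor 1 (Homo sapiens), read by inositol phosphate accumulation (on this read-out lower numbers stand for stronger inhibition and higher numbers for weaker inhibition), compound 1 gives > 10000 nM, which is a limit of the assay.
Compound 2 `Cc1nc(N2CCC(C)(O)CC2)nc2ccc(NC(=O)COc3ccc(Cl)cc3)cc12`: compound 2 gives 827 nM.
Compound 3 `Cc1nc(N2CCN(C(=O)C3CC3)CC2)nc2ccc(NC(=O)COc3ccc(OC(F)(F)F)cc3)cc12`: compound 3 gives 30 nM.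

Of the two numbers actually measured, compound 2 stands highest; compound 3 sits lower by a gap beyond the scatter, though compound 3 also carries a different substituted phenoxy group, so the two are not a single-point pair. Within the data shown here, the only single-point step is an at least 12-fold lower number from compound 1 to compound 2 (1.08 log units; beyond the scatter), a large move away from the limit.

Compound 4 `Cc1nc(N2CCN(C)CC2)nc2ccc(NC(=O)COc3ccc(Cl)cc3)cc12` differs from compound 2 by 4-methylpiperazin-1-yl in place of 4-hydroxy-4-methylpiperidin-1-yl on an aromatic carbon. This returns to a piperazine, the ring class seen in compound 1 with a methylsulfonyl group and in compound 3 with a cyclopropanecarbonyl group; those two measured piperazines sit at opposite ends of the range shown, so they point in no single direction, and no measured pair changes only the group on the second ring nitrogen. A modest move toward a lower number is therefore expected, with wide uncertainty: compound 4 is estimated at 300 nM, between 50 nM and 3000 nM, a step of a 2.8-fold lower number from compound 2 to compound 4 (0.44 log units; beyond the scatter).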

Compound 4, half-maximal inhibitory concentration: 3800 nM
Compound 4: the middle estimate sits 13-fold (1.10 log units) below what was measured; the whole stated range lies below it.
By their numbers in this assay, from the lowest: compound 3; then compound 2; then compound 4. At a limit, above all of these: compound 1.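

In this assay, the ring at this position matters even when it stays a six-membered non-aromatic amine ring: a 4.6-fold higher number from compound 2 to compound 4 (0.66 log units; beyond the scatter), so the piperazine is not the better of the two here, and the entering 4-methylpiperazin-1-yl carries no hydrogen-bond donor, though these compounds cannot say whether that loss is what counts. Among these compounds, the group on the second ring nitrogen also matters, as the first pair changing only that group shows an at least 2.6-fold lower number from compound 1 to compound 4 (0.42 log units; beyond the scatter), with methyl in place of methylsulfonyl. Compound 1 stands at a limit, so that step gives only a minimum size: the limit of > 10000 nM in this assay, at which 1 of the 4 values shown sits.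

From the compounds shown here alone, what the cyclopropanecarbonyl group contributes in compound 3 remains open, since that compound also carries a different phenoxy group. Also open, going by these compounds, is how a piperazine with an unsubstituted ring nitrogen or a morpholine ring would behave at this position.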